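The compounds below may be only part of what the source reports. "The series", "measured", "known", "first", "only" and "open" are said of these compounds alone.

Measured compounds: compound 1 `CCc1ccccc1NC(=O)N[C@@H](C)c1ccccc1` gives 95%; compound 2 `C[C@H](NC(=O)Nc1ccccc1C(F)(F)F)c1ccccc1` gives 97%; compound 3 `CC(=O)c1ccccc1NC(=O)N[C@H](C)c1ccccc1` gives 89%.

In an ADME assay on the whole organism with Oryza sativa as the target, tested at 10 uM (on this read-out lower numbers stand for a stronger effect and higher numbers for a weaker effect at the one concentration tested), compound 3 gives the lowest of the three numbers as read, yet its gap to compound 1 and its gap to compound 2 both lie within the scatter, so nothing separates these three with confidence. Compound 4 `CC(=O)c1ccccc1NC(=O)N[C@@H](C)c1ccccc1` has not yet been measured. It differs from compound 3 as follows: the two compounds have the same atoms and bonds and differ only in configuration as drawn: 1 of 1 stereo elements differ; a stereocentre at a saturated chain carbon is drawn R in compound 3 and S in compound 4. Among the measured compounds shown here, no measured step changes a stereocentre; the only measured step, a number 2 percentage points higher from compound 1 to compound 2 (within the scatter), alters a group on an aromatic carbon and lies within the scatter, so it offers little guidance here. For the measured compounds named here, with no comparable step to draw on, compound 4 is expected to sit close to compound 3, and the expected step of a number 1 percentage points higher from compound 3 to compound 4 (within the scatter) is one within the scatter. Compound 4 is therefore estimated at 90% in this assay, in a range from 80% to 99%.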

Compound 4, a percentage reported as activity, at one concentration (the size of the read-out at that concentration, not a potency): 96%
Compound 4: middle estimate off by 6 percentage points, on the low side; measured number inside the range.
By their numbers in this assay, from the lowest: compounds 3, 1, 4 and 2 (each within the scatter of the next).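

In this assay, the change of configuration at the saturated chain carbon gives a number 7 percentage points higher from compound 3 to compound 4 (within the scatter), so this stereocentre change does not separate the pair with confidence: the fact that compounds 3 and 4 differ only in the configuration as drawn. On the aromatic carbon, acetyl in place of ethyl gives a number 1 percentage points higher from compound 1 to compound 4 (within the scatter), and acetyl in place of trifluoromethyl gives a number 1 percentage points lower from compound 2 to compound 4 (within the scatter). Neither the configuration nor any of these three groups on the aromatic carbon is therefore set apart in this read-out.

From the compounds shown here alone, it remains open whether an amine or a carboxylic acid on that aromatic carbon would give a step beyond the scatter, and whether the configuration would then matter.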